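The source may hold more compounds than are shown below. What is called first, only, known or untested is meant among the compounds shown, and "the series" means these compounds.

Measured compounds in a functional assay on MCF7 cells (Homo sapiens) for antiproliferative activity, read by MTT assay, with a stated time of 48 h; a lower number here means a stronger inhibitor, a higher number a weaker inhibitor:

- compound 1 `O=C(Nc1cccc(/C=C/C(=O)c2nc3ccccc3[nH]2)c1)c1cccc(Cl)c1`: 7840 nM
- compound 2 `O=C(/C=C/c1cccc(NC(=O)c2ccccc2Br)c1)c1nc2ccccc2[nH]1`: 4520 nM
- compound 3 `O=C(/C=C/c1cccc(NS(=O)(=O)c2ccccc2Cl)c1)c1nc2ccccc2[nH]1`: 4280 nM

The three numbers sit close together. Compound 1 gives the highest of them, yet its step to compound 2 a 1.7-fold lower number from compound 1 to compound 2 (0.24 log units; within the scatter) and its step to compound 3 a 1.8-fold lower number from compound 1 to compound 3 (0.26 log units; within the scatter) both lie within the scatter, so no ordering can be read from the set. The step between compound 2 and compound 3 a 1.1-fold lower number from compound 2 to compound 3 (0.02 log units; within the scatter) is likewise flat.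

Compound 4 `Cc1cccc(S(=O)(=O)Nc2cccc(/C=C/C(=O)c3nc4ccccc4[nH]3)c2)c1` is not yet measured in this assay. Relative to compound 1 it carries (3-methylphenyl)sulfonyl in place of (3-chlorophenyl)carbonyl on a nitrogen on an aromatic ring. Among the compounds with values here, the step that bears on this most directly is the one from compound 1 to compound 3, where a sulfonyl-linked aryl took the place of the carbonyl-linked aryl and the number moved a 1.8-fold lower number from compound 1 to compound 3 (0.26 log units; within the scatter). The exchange of carbonyl for sulfonyl between compound 2 and compound 3 gave a 1.1-fold lower number from compound 2 to compound 3 (0.02 log units; within the scatter). Both stay within the scatter, and nothing in the set addresses the methyl for chlorine swap on its own. The expectation for compound 4 is therefore a step of about a 1.6-fold lower number from compound 1 to compound 4 (0.20 log units; within the scatter), not beyond the scatter. Compound 4 is estimated at 5000 nM, with a range of 2500 nM to 10000 nM.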

Compound 4, half-maximal inhibitory concentration: 886 nM
For compound 4 the middle estimate is 5.6-fold (0.75 log units) above the measured one, and the stated range ends above it.
By their numbers in this assay, from the lowest: compound 4; then compounds 3, 2 and 1 (each within the scatter of the next).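

In this assay, the nitrogen on an aromatic ring now shows a change beyond the scatter: (3-methylphenyl)sulfonyl gives an 8.8-fold lower number from compound 1 to compound 4 (0.95 log units; beyond the scatter) and a 5.1-fold lower number from compound 2 to compound 4 (0.71 log units; beyond the scatter). Sulfonyl is present in both compound 3 and compound 4, yet 3-methylphenyl in place of 2-chlorophenyl on the sulfonyl sulfur gives a 4.8-fold lower number from compound 3 to compound 4 (0.68 log units; beyond the scatter), so the sulfonyl link alone does not go with the lower number, and the aryl group on it matters in this set. No measurement at hand accounts for this step.

Open, from the compounds shown here alone, is which part of the exchange of 2-chlorophenyl for 3-methylphenyl carries the step, the methyl group or where it stands on the phenyl. Also open, going by these compounds, is how a methoxy group, an amine or a longer alkyl chain in place of that methyl would read in this assay.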